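Adding Fluoro to the Phenyl Ring of Compound 3

A few compounds are considered here, and "the series" means these few. Any claim that something is new, unique, unknown or untested is made for them only; others in the source may bear on it.

Going by the values given here, in a functional assay on MCF7 cells (Homo sapiens) for cytotoxicity, read by MTT assay, with a stated time of 72 h (a higher number here means a weaker inhibitor, a lower number a stronger inhibitor), compound 3 (`CNC(=O)c1cc(Oc2ccc(C3=NNC(c4ccccc4)C3)cc2)ccn1`) gives 1240 nM and compound 1 (`CNC(=O)c1cc(Oc2ccc(C3=NNC(c4cccc(Br)c4)C3)cc2)ccn1`) gives 1960 nM as the only other number, so the two stand within the scatter of each other. Compound 2 (`CNC(=O)c1cc(Oc2ccc(C3=NNC(c4ccc([N+](=O)[O-])cc4)C3)cc2)ccn1`) carries the result "not determined" (no result reported) and so offers no comparison.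

Compound 4 (`CNC(=O)c1cc(Oc2ccc(C3=NNC(c4ccc(F)cc4)C3)cc2)ccn1`) has not yet been measured. It differs from compound 3 by a single change (fluoro in place of hydrogen on an aromatic carbon), fluoro in place of hydrogen on an aromatic carbon, which turns phenyl to 4-fluorophenyl.

Among the compounds with values here, only one measured step bears on this change: a 1.6-fold lower number from compound 1 to compound 3 (0.20 log units; within the scatter) with hydrogen in place of bromo on an aromatic carbon. Within the data shown here, that step concerns bromo rather than fluoro, and no compound carrying fluoro has a measured value yet, so it is only a loose guide. With compound 1 and compound 3 this close, no step beyond the scatter is expected, and the estimated change is a 1.1-fold higher number from compound 3 to compound 4 (0.05 log units; within the scatter) with no clear direction expected. For compound 4 the estimated value is 1400 nM with a range from 700 nM to 2800 nM expected.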

Compound 4, half-maximal inhibitory concentration: 9480 nM
Estimate against measurement, compound 4: 6.8-fold (0.83 log units) below; measured number outside the range, above it.
By their numbers in this assay, from the lowest: compounds 3 and 1 (each within the scatter of the next); then compound 4.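

In this assay the phenyl ring of the series proves sensitive to a single added atom: fluoro in place of hydrogen on an aromatic carbon, para to a large group, gives a 7.6-fold higher number from compound 3 to compound 4 (0.88 log units; beyond the scatter) and so moves the number well beyond the scatter, which the earlier exchange of bromo for hydrogen did not do. Set against the 3-bromophenyl analogue, the 4-fluorophenyl group gives a 4.8-fold higher number from compound 1 to compound 4 (0.68 log units; beyond the scatter) as well, so compound 4 holds the highest number of the three and stands apart from compound 3 and compound 1, which remain within the scatter of each other. Nothing available accounts for why this small change carries such a step.

On these data alone, whether the loss belongs to fluoro itself or to any group at this place stays open, since compound 2, the 4-nitrophenyl analogue, offers no number to compare, and a single fluoro result cannot separate the two readings. As far as these compounds go, how a chloro, a methoxy or an amine would behave at this place, and whether fluoro would give a similar step at another place on the ring, also remains unknown.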